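A few compounds are considered here, and "the series" means these few. Any claim that something is new, unique, unknown or untested is made for them only; others in the source may bear on it.

Within the data shown here, the three compounds measured so far share one core and differ only in the group carried on a triple-bonded carbon. Compound 1 `COC(=O)c1sc2cc(C#Cc3ccccn3)cnc2c1N` gives 34900 nM in a functional assay on NCI-H460 cells (Homo sapiens) for inhibition, read by sulforhodamine B assay, with a stated time of 48 h; a lower number here means a stronger inhibitor of growth, a higher number a weaker inhibitor of growth. Compound 2 `COC(=O)c1sc2cc(C#Cc3ccc(OC)cc3)cnc2c1N` gives 320 nM. Compound 3 `COC(=O)c1sc2cc(C#Cc3ccsc3)cnc2c1N` gives 24800 nM. Among these three numbers compound 3 stands second highest, close to compound 1 and far from compound 2: a 1.4-fold lower number from compound 1 to compound 3 (0.15 log units; within the scatter), while a 78-fold higher number from compound 2 to compound 3 (1.89 log units; beyond the scatter).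

Compound 4 `COC(=O)c1sc2cc(C#Cc3ccc(F)cc3)cnc2c1N` has not yet been measured. It differs from compound 3 in one place: 4-fluorophenyl in place of thiophen-3-yl on a triple-bonded carbon. Among the measured compounds shown here, two measured steps bear on this change, and both involve the 4-methoxyphenyl group moving the number a long way: a 110-fold lower number from compound 1 to compound 2 (2.04 log units; beyond the scatter), and in the other direction a 78-fold higher number from compound 2 to compound 3 (1.89 log units; beyond the scatter). For the measured compounds named here, the entering group of compound 4 is again a six-membered ring of carbon only, but it carries fluorine rather than methoxy, and no measured pair shows what that difference alone does. A large step downward from compound 3 is therefore expected, though perhaps not the full size seen with compound 2. For compound 4 the expected step is a 17-fold lower number from compound 3 to compound 4 (1.22 log units; beyond the scatter). Compound 4 is estimated at 1500 nM, with a range from 300 nM to 8000 nM.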

Compound 4, concentration for 50% growth inhibition: 24000 nM
Compound 4: the middle estimate sits 16-fold (1.20 log units) below what was measured; the measured number lies above the stated range.
By their numbers in this assay, from the lowest: compound 2; then compounds 4, 3 and 1 (each within the scatter of the next).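

In this assay, the 4-fluorophenyl group does no better than the two other rings: the result is a 1.0-fold lower number from compound 3 to compound 4 (0.01 log units; within the scatter) and a 1.5-fold lower number from compound 1 to compound 4 (0.16 log units; within the scatter), both within the scatter, so a six-membered ring of carbon only on the triple-bonded carbon is not enough to reach the low number of compound 2. The sharpest information comes from the new pair in which only the group on the phenyl ring changes, with fluoro in place of methoxy on an aromatic carbon: a 75-fold higher number from compound 2 to compound 4 (1.88 log units; beyond the scatter), so among these compounds the strong growth inhibition of compound 2 depends on methoxy and not on the phenyl ring alone. Nothing shown here explains why these two groups differ so widely.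

The compounds shown leave open whether methoxy is unique at this spot, or whether an ethoxy group, a hydroxyl or an amine in its place would also give a low number, and where an unsubstituted phenyl ring would fall. They also leave open whether the methoxy effect would survive if the methyl ester on the shared core became a carboxylic acid or an amide.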